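Dropping the Nitro Group on Two Related Cores

This account rests on a few compounds, and the source may have more. Where it says the series, first, only, none or still open, it means among the compounds named here.

Compound 2 `O=[N+]([O-])c1ccc(COc2cccc(Nc3ncnc4cc5c(cc34)OCCOCCO5)c2)cc1` and compound 3 `c1ccc(COc2cccc(Nc3ncnc4cc5c(cc34)OCCOCCO5)c2)cc1` share one core and differ only by hydrogen in place of nitro on an aromatic carbon. In a functional assay on A549 cells (Homo sapiens) for antiproliferative activity, read by MTT assay, with a stated time of 72 h (a lower number here means a stronger inhibitor, a higher number a weaker inhibitor), compound 2 gives 15500 nM, while compound 3 gives 7590 nM, so the change made a 2.0-fold lower number from compound 2 to compound 3 (0.31 log units; beyond the scatter). Compound 1 `O=[N+]([O-])c1ccc(COc2ccc(Nc3ncnc4cc5c(cc34)OCCOCCOCCOCCO5)cc2)cc1` is built on another core; the difference between the two cores is not broken down here. In this assay compound 1 reaches only a limit of the assay, > 100000 nM, as noted in the limit of > 100000 nM in this assay, at which 1 of the 3 values shown sits. Compound 4 `c1ccc(COc2ccc(Nc3ncnc4cc5c(cc34)OCCOCCOCCOCCO5)cc2)cc1` differs from compound 1 by the same change, (hydrogen in place of nitro on an aromatic carbon). Compound 4 is expected to land at about 80000 nM, somewhere between 30000 nM and 300000 nM. That expectation means a step of an at least 1.2-fold lower number from compound 1 to compound 4 (0.09 log units; that floor lies within the scatter), and it rests on a 2.0-fold lower number from compound 2 to compound 3 (0.31 log units; beyond the scatter) together with the fact that compound 1 shows only a limit.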

Compound 4, half-maximal inhibitory concentration: 29500 nM
Beside the measured number, compound 4's estimate is 2.7-fold (0.43 log units) above it; measured number outside the range, below it.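

On the second core, hydrogen in place of nitro gives an at least 3.3-fold lower number from compound 1 to compound 4 (0.53 log units; beyond the scatter) in this assay, so the number falls in the same direction on both cores shown. Whether the size of the step carries over from one core to the other cannot be said: the same change on two cores in this assay, a 2.0-fold lower number (0.31 log units; beyond the scatter) from compound 2 to compound 3 and an at least 3.3-fold lower number (0.53 log units; beyond the scatter) from compound 1 to compound 4; the limit leaves it open whether they differ Compound 1 gives only a limit of the assay, > 100000 nM, and two cores are too few to make this a rule for the whole series.

From the compounds shown here alone, whether an amine or a carboxylic acid on the same aromatic carbon would shift the number as hydrogen does remains open. Also open, going by these compounds, is how much the difference between the two cores contributes by itself.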